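Shifting the chlorine from 3-chlorobenzyl to 4-chlorobenzyl

The compounds below may be only part of what the source reports. "The series", "measured", "known", "first", "only" and "open" are said of these compounds alone.

In a functional assay on A549 cells (Homo sapiens) for cytotoxicity, read by MTT assay, with a stated time of 72 h (a higher number here means a weaker inhibitor, a lower number a stronger inhibitor), compound 3 `CCN(CC)Cc1ccc2nc(NC(=O)N/N=C/c3cn(Cc4cccc(Cl)c4)c4ccccc34)sc2c1` gives 2410 nM. That value lies within the scatter of the two other measured compounds, compound 1 `CCN(CC)Cc1ccc2nc(NC(=O)N/N=C/c3cn(Cc4ccc(C(C)(C)C)cc4)c4ccccc34)sc2c1` at 1710 nM and compound 2 `CC1CCN(Cc2ccc3nc(NC(=O)N/N=C/c4cn(Cc5cccc(Cl)c5)c5ccccc45)sc3c2)CC1` at 2810 nM. Compound 4 `CCN(CC)Cc1ccc2nc(NC(=O)N/N=C/c3cn(Cc4ccc(Cl)cc4)c4ccccc34)sc2c1` has 4-chlorophenyl in place of 3-chlorophenyl on a saturated chain carbon bound to an aromatic nitrogen. The closest evidence is a 1.4-fold higher number from compound 1 to compound 3 (0.15 log units; within the scatter), a change at this same place. The other measured step, a 1.2-fold lower number from compound 2 to compound 3 (0.07 log units; within the scatter), lies elsewhere on the molecule. Within the data shown here, no measured pair compares these two chlorophenyl groups directly, so no change beyond the scatter is expected. The expected step is a 1.1-fold lower number from compound 3 to compound 4 (0.04 log units; within the scatter). For compound 4, the estimated value is 2200 nM, with an expected range of 1100 nM to 4400 nM.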

Compound 4, half-maximal inhibitory concentration: 2940 nM
Compound 4: middle estimate off by 1.3-fold (0.13 log units), on the low side; low and high end bracket the measured number.
By their numbers in this assay, from the lowest: compounds 1, 3, 2 and 4 (each within the scatter of the next).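

Moving the chlorine from 3-chlorobenzyl to 4-chlorobenzyl gives a 1.2-fold higher number from compound 3 to compound 4 (0.09 log units; within the scatter) in this assay and so shows that, at this place, where the chlorine sits on the ring changes the number no more than repeat measurements would. Chloro in place of tert-butyl gives a 1.7-fold higher number from compound 1 to compound 4 (0.24 log units; within the scatter) and this too stays inside the usual scatter, so the three benzyl groups shown cannot be told apart here. No measurement shown offers an explanation for this. From the compounds shown here alone, whether an amine or a carboxylic acid on this ring would move the number beyond the scatter stays open.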